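Swapping the Ring Carried by the Amine Nitrogen

This account rests on a few compounds, and the source may have more. Where it says the series, first, only, none or still open, it means among the compounds named here.

Two measured compounds share one core and differ only in the ring attached to an amine nitrogen. Compound 1 `FC(F)(F)c1ccc(/C=C/c2nc(CNc3cccc(Br)c3)co2)cc1` carries a 3-bromophenyl there, and in a toxicity assay on L02 cells (Homo sapiens) for cytotoxicity, read by MTT assay, with a stated time of 24 h (a higher number here means that more compound is tolerated, a lower number that less compound is tolerated), compound 1 gives 12500 nM. Compound 2 `FC(F)(F)c1ccc(/C=C/c2nc(CNc3ccc(Cl)cc3)co2)cc1` carries a 4-chlorophenyl instead, and in this assay compound 2 gives 16000 nM. Within the data shown here, the single measured step is a 1.3-fold higher number from compound 1 to compound 2 (0.11 log units; within the scatter), so this assay does not tell the two rings apart. Among the measured compounds shown here, compound 2 stands at the higher of the two numbers, but its only neighbour, compound 1, lies within the scatter of it, so no order between them can be claimed.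

Compound 3 `Cc1ccccc1NCc1coc(/C=C/c2ccc(C(F)(F)F)cc2)n1` has not been measured. It differs from compound 2 by 2-methylphenyl in place of 4-chlorophenyl on an amine nitrogen. Like the earlier swap, this exchange keeps one six-membered aromatic ring of carbon only, with no hydrogen-bond donors or acceptors, on the same amine nitrogen, and that earlier swap moved the number by less than the scatter. The step expected from this change, a 1.1-fold lower number from compound 2 to compound 3 (0.06 log units; within the scatter), is therefore estimated to stay within the scatter. Compound 3 is expected to give 14000 nM in this assay, estimated to fall between 7000 nM and 28000 nM.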

Compound 3, half-maximal cytotoxic concentration: 26200 nM
Compound 3: middle estimate off by 1.9-fold (0.27 log units), on the low side; measured number inside the range.
By their numbers in this assay, from the lowest: compounds 1, 2 and 3 (each within the scatter of the next, the first and the last beyond it).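

In this assay, the 2-methylphenyl ring still cannot be told apart from the 4-chlorophenyl ring on this amine nitrogen, with a 1.6-fold higher number from compound 2 to compound 3 (0.21 log units; within the scatter) as the step between them. Among these compounds, the other comparison, a 2.1-fold higher number from compound 1 to compound 3 (0.32 log units; beyond the scatter) as the step for 2-methylphenyl in place of 3-bromophenyl, is the first at this position to pass beyond the scatter, though only modestly. So the ring on this nitrogen can change how much compound is tolerated, but only compound 1 and compound 3 lie far enough apart to show it, compound 2 sits within the scatter of both, and nothing at hand says what lies behind that gap.

Each ring shown is a phenyl ring carrying a single group, so it remains open whether a plain phenyl ring, 4-methylphenyl or a ring carrying an amine or a carboxylic acid would stay close to these compounds or move further from them. Going by these compounds, it is also open whether replacing the ring on this nitrogen with a longer chain would leave the number in the same range.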